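Ring-closed amines on a chalcone scaffold

The compounds below may be only part of what the source reports. "The series", "measured", "known", "first", "only" and "open" are said of these compounds alone.

Compound 1 `CCN(C)Cc1c(OC)cc(OC)c(C(=O)/C=C/c2ccccc2Cl)c1O`: 1300 nM
Compound 2 `COc1cc(OC)c(C(=O)/C=C/c2ccccc2Cl)c(O)c1CN1CCCCC1`: 2800 nM
Compound 3 `COc1cc(OC)c(C(=O)/C=C/c2ccccc2Cl)c(O)c1CN(C)C`: 2100 nM

Three analogues sharing one core have been tested in a functional assay on A549 cells (Homo sapiens) for antiproliferative activity, with a stated time of 72 h; on this read-out higher numbers stand for weaker inhibition and lower numbers for stronger inhibition. Compound 3 stands second highest of the three numbers; its nearest neighbour is compound 2 at a 1.3-fold lower number from compound 2 to compound 3 (0.12 log units; within the scatter), and its furthest is compound 1 at a 1.6-fold higher number from compound 1 to compound 3 (0.21 log units; within the scatter), both within the scatter.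

Compound 4 `COc1cc(OC)c(C(=O)/C=C/c2ccccc2Cl)c(O)c1CN1CCCC1` differs from compound 3 by pyrrolidin-1-yl in place of dimethylamino on a saturated chain carbon bound to an aromatic carbon. For the measured compounds named here, two measured steps bear on this change. The step of a 2.2-fold higher number from compound 1 to compound 2 (0.33 log units; beyond the scatter) is modest and beyond the scatter, while the step of a 1.3-fold lower number from compound 2 to compound 3 (0.12 log units; within the scatter) is within it. The amine in compound 4 has a ring, like that of compound 2, but smaller, so a step in this assay of at most modest size, if any, is expected for a 1.2-fold higher number from compound 3 to compound 4 (0.08 log units; within the scatter), in the direction of a somewhat higher number. The estimate for compound 4 is therefore 2500 nM, with a range from 1200 nM to 5000 nM.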

Compound 4, half-maximal inhibitory concentration: 2600 nM
The estimate for compound 4 lay 1.0-fold (0.02 log units) below the measured number, within the range that was stated.
By their numbers in this assay, from the lowest: compounds 1, 3, 4 and 2 (each within the scatter of the next, the first and the last beyond it).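

In this assay, closing the amine into a five-membered ring leaves the number within the scatter (a 1.2-fold higher number from compound 3 to compound 4 (0.09 log units; within the scatter)), even though pyrrolidin-1-yl carries more heavy atoms than dimethylamino. The two ring sizes also stay within the scatter of each other (a 1.1-fold lower number from compound 2 to compound 4 (0.03 log units; within the scatter)). The step from ethyl(methyl)amino to pyrrolidin-1-yl (a 2.0-fold higher number from compound 1 to compound 4 (0.30 log units; within the scatter)) is within the scatter as well, whereas the step to piperidin-1-yl (a 2.2-fold higher number from compound 1 to compound 2 (0.33 log units; beyond the scatter)) lies beyond it, so at this position on a saturated chain carbon bound to an aromatic carbon, these compounds show no clear separation of ring-closed from open amines.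

Nothing shown gives a cause for these values. On these data alone, it remains open whether a ring with a second hetero atom, such as morpholin-4-yl or 4-methylpiperazin-1-yl, or an unsubstituted primary amine, would give a number within the same scatter.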